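Methoxy in Place of Fluoro on a Shared Core

The source may report more compounds than this note shows. Statements on the series, on what has been measured and on what is new or still open speak of the compounds shown alone.

Compound 1 `Nc1cc(N)c2nc(-c3ccccc3)c(Sc3ccc(F)cc3)nc2c1` was tested in a functional assay on SN12C cells (Homo sapiens) for inhibition, read by sulforhodamine B assay, with a stated time of 48 h; a lower number here means a stronger inhibitor of growth, a higher number a weaker inhibitor of growth. In this assay compound 1 gives < 100000 nM, and that figure is a limit of the assay rather than a measured number (the limit of < 100000 nM in this assay, at which 1 of the 2 values shown sits). A second compound, compound 2 `COc1cc(CNc2nc3cc(N)cc(N)c3nc2-c2ccccc2)cc(OC)c1OC`, shares the same core but carries a different attachment at the same position. In this assay compound 2 gives 8710 nM. Among the measured compounds shown here, the two compounds differ in more than one place, so their values show only that compound 2 has a number where compound 1 has a limit.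

Compound 3 `COc1ccc(Sc2nc3cc(N)cc(N)c3nc2-c2ccccc2)cc1` is not yet measured. It differs from compound 1 in a single place: methoxy in place of fluoro on an aromatic carbon. Put another way, the (4-fluorophenyl)sulfanyl group becomes a (4-methoxyphenyl)sulfanyl group. For the measured compounds named here, with only a limit for compound 1, no measured step anchors the direction. The step from compound 1 to compound 3 is expected to be a step that the limit leaves unreadable from compound 1 to compound 3, with no clear direction beyond the scatter. Compound 3 is expected to give about 20000 nM, within a range from 5000 nM to 80000 nM.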

Compound 3, concentration for 50% growth inhibition: 6030 nM
Beside the measured number, compound 3's estimate is 3.3-fold (0.52 log units) above it; low and high end bracket the measured number.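

Among the compounds shown here, no step from compound 1 to compound 3 can be read, since in this assay compound 1 gives < 100000 nM as a limit of the assay and not a number: the limit of < 100000 nM in this assay, at which 1 of the 3 values shown sits.

The compounds shown leave open how far, and in which direction, methoxy in place of fluoro shifts growth inhibition on this shared core.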